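The source may hold more compounds than are shown below. What is called first, only, known or untested is meant among the compounds shown, and "the series" means these compounds.

Compound 1 `COc1cc(C(=O)c2sc(-c3ccc(F)cc3)cc2N)cc(OC)c1OC`: 20 nM
Compound 2 `COc1cc(C(=O)c2sc(-c3ccc(Cl)c(Cl)c3)cc2N)cc(OC)c1OC`: 260 nM
Compound 3 `COc1ccc(-c2cc(N)c(C(=O)c3cc(OC)c(OC)c(OC)c3)s2)cc1OC`: 40 nM

Of the compounds shown here, three sharing one core have been measured in a functional assay on L1210 cells (Mus musculus) for antiproliferative activity; a lower number here means a stronger inhibitor, a higher number a weaker inhibitor. Compound 1 gives the lowest number of the three. Compound 3 is nearest to it, and the step of a 2.0-fold higher number from compound 1 to compound 3 (0.30 log units; within the scatter) is within the scatter, so these two cannot be ranked against each other. Compound 2 stands furthest away, and the step of a 13-fold higher number from compound 1 to compound 2 (1.11 log units; beyond the scatter) is large.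

Compound 4 `COc1cc(C(=O)c2sc(-c3ccc(-c4ccccc4)cc3)cc2N)cc(OC)c1OC` has not yet been measured. It differs from compound 1 at one place: phenyl in place of fluoro on an aromatic carbon. The phenyl enters on an aromatic carbon of a six-membered aromatic ring of carbon only, where the fluoro leaves.

For the measured compounds named here, no measured step exchanges fluoro for phenyl, so the existing steps bear on this change only indirectly. Both alterations of the same aromatic ring, a 13-fold higher number from compound 1 to compound 2 (1.11 log units; beyond the scatter) and a 2.0-fold higher number from compound 1 to compound 3 (0.30 log units; within the scatter), show that reworking this ring can cost a great deal or almost nothing, and the costlier of the two was the one that kept halogens there. A phenyl is a larger replacement than either, so a higher number is expected for compound 4, probably beyond the scatter, though its size is uncertain.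

Compound 4 is therefore estimated at 200 nM, with a range from 40 nM to 1500 nM. The expected step for compound 4 is a 10-fold higher number from compound 1 to compound 4 (1.00 log units; beyond the scatter).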

Compound 4, half-maximal inhibitory concentration: > 10000 nM
Compound 4: a limit, no number; the forecaster's own chance of this, stated with the estimate: 5%; middle value at least 50-fold (1.69 log units) away from the limit.
By their numbers in this assay, from the lowest: compounds 1 and 3 (each within the scatter of the next); then compound 2. At a limit, above all of these: compound 4.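

Putting a phenyl in place of the fluoro on this aromatic carbon, para to a large group, gives an at least 500-fold higher number from compound 1 to compound 4 (2.69 log units; beyond the scatter) in this assay. Compound 4 stands at a limit, not at a number: the limit of > 10000 nM in this assay, at which 1 of the 4 values shown sits. The earlier changes to this ring all left a measurable value, with compound 3 even staying within the scatter of compound 1, so the ring's tolerance seen so far does not extend to every replacement, and phenyl, the only group shown here that brings a ring of its own, is the first change to lose the measurable value.

Going by these compounds, one compound cannot separate the effect of adding a second ring from the effect of simply adding more atoms at this place, and because the result is a limit, the true size of the loss also stays unknown. On these data alone, it remains open whether a small methyl, a longer chain such as butyl, a saturated ring such as cyclohexyl or an amine at this same place would keep a measurable value, and so where along that series the activity gives way.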